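Cytotoxicity notes on amine side-chain variation in the shared core

The source may hold more compounds than are shown below. What is called first, only, known or untested is meant among the compounds shown, and "the series" means these compounds.

Compound 1, `O=C1c2c[n+]([O-])c3ccccc3c2C(=O)c2c1c1ccccc1n2Cc1cn([C@@H]2C[C@H](O)[C@@H](CO)O2)nn1`: in a toxicity assay on L02 cells (Homo sapiens) for cytotoxicity, read by MTT assay, with a stated time of 72 h (on this read-out higher numbers stand for weaker inhibition and lower numbers for stronger inhibition), compound 1 gives 630 nM.
Compound 2, `CC1(C)OCC(Cn2cc(Cn3c4c(c5ccccc53)C(=O)c3c[n+]([O-])c5ccccc5c3C4=O)nn2)O1`: in this assay compound 2 gives 120 nM.
Compound 3, `O=C1c2c[n+]([O-])c3ccccc3c2C(=O)c2c1c1ccccc1n2CCN1CCCC1`: in this assay compound 3 gives 930 nM.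

Compound 3 stands highest of the three numbers; compound 1 lies within the scatter of it, whereas compound 2 is clearly lower. Going by the values given here, the only single-point step measured is a 5.3-fold lower number from compound 1 to compound 2 (0.72 log units; beyond the scatter), which concerns the group on the aromatic nitrogen and not the amine at the end of the chain.

Compound 4 `CN1CCN(CCCCCn2c3c(c4ccccc42)C(=O)c2c[n+]([O-])c4ccccc4c2C3=O)CC1` differs from compound 3 by 3-(4-methylpiperazin-1-yl)propyl in place of pyrrolidin-1-yl on a saturated chain carbon, two bonds along the chain from an aromatic nitrogen. Among the compounds with values here, no measured step bears on this kind of change, so nothing beyond the scatter is expected; compound 4 is estimated to show a 1.0-fold lower number from compound 3 to compound 4 (0.01 log units; within the scatter) in this assay. The estimate for compound 4 is therefore 900 nM, with a range from 300 nM to 2700 nM.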

Compound 4, half-maximal inhibitory concentration: 1640 nM
Beside the measured number, compound 4's estimate is 1.8-fold (0.26 log units) below it, and the stated range covers the measured number.
By their numbers in this assay, from the lowest: compound 2; then compounds 1, 3 and 4 (each within the scatter of the next, the first and the last beyond it).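

In this assay, going by these compounds alone, a 1.8-fold higher number from compound 3 to compound 4 (0.25 log units; within the scatter), so this is the first measured step at the amine end of the chain, and the exchange of pyrrolidin-1-yl for 3-(4-methylpiperazin-1-yl)propyl stays within the scatter. At this place, on a saturated chain carbon, the larger group thus brings no clear shift in the number. No measurement at hand offers an explanation of this result.

As far as these compounds go, the ring and the chain length change together in this step, and their separate contributions remain open. A morpholine on the two-carbon chain would test the ring alone, and a longer chain ending in pyrrolidin-1-yl would test the length alone.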